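The source may report more compounds than this note shows. Statements on the series, on what has been measured and on what is new or still open speak of the compounds shown alone.

Measured compounds in an assay on isolated protein for activation of cGMP-dependent protein kinase 1 (Homo sapiens), read by ADP-Glo, with stated times of 120 min and 40 min; on this read-out higher numbers stand for an effect only at larger amounts of compound and lower numbers for an effect already at smaller amounts:
compound 1, `O=C(O)c1ccc(CN2CCC[C@H](OCc3cc(Cl)cc(Cl)c3)[C@@H]2c2ccccc2)s1`, gives 76000 nM.
compound 2, `Clc1cc(Cl)cc(CO[C@H]2CCCN(Cc3ccccn3)[C@H]2c2ccccc2)c1`, gives only a limit of the assay, > 200000 nM.
compound 3, `COC(=O)Nn1c(C[C@H]2CCC[C@H](OCc3cc(C(F)(F)F)cc(C(F)(F)F)c3)[C@@H]2c2ccccc2)n[nH]c1=O`, gives 4500 nM.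

Compound 2 stands at the boundary of the numbers shown: its value is a limit, not a number, and it sits at the limit of > 200000 nM in this assay, at which 1 of the 3 values shown sits. Compound 1 and compound 3 each give a number.

Compound 4, `O=C(O)c1cncc(CN2CCC[C@H](OCc3cc(Cl)cc(Cl)c3)[C@@H]2c2ccccc2)c1`, differs from compound 2 by 5-carboxypyridin-3-yl in place of pyridin-2-yl on a saturated chain carbon bound to an amine nitrogen in a ring. Among the measured compounds shown here, the one measured step at this place is an at least 2.6-fold higher number from compound 1 to compound 2 (0.42 log units; beyond the scatter), in which 5-carboxythiophen-2-yl gave way to pyridin-2-yl and the number rose beyond the scatter. The change to compound 4 runs the other way, bringing a carboxy-substituted ring, 5-carboxypyridin-3-yl, back onto that carbon, though on a different ring than in compound 1. A modest fall in number, roughly the reverse of that step, is therefore expected from compound 2 to compound 4, an at least 2.0-fold lower number from compound 2 to compound 4 (0.30 log units; that floor lies within the scatter). Compound 4 is estimated at 100000 nM in this assay, with a range from 30000 nM to 300000 nM, and a real chance remains that only a limit is reported.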

Compound 4, half-maximal effective concentration: 117000 nM
For compound 4 the middle estimate is 1.2-fold (0.07 log units) below the measured one; the measured number falls inside the stated range.
By their numbers in this assay, from the lowest: compound 3; then compounds 1 and 4 (each within the scatter of the next). At a limit, above all of these: compound 2.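

On a saturated chain carbon bound to an amine nitrogen in a ring, 5-carboxypyridin-3-yl in place of pyridin-2-yl gives an at least 1.7-fold lower number from compound 2 to compound 4 (0.23 log units; that floor lies within the scatter). This step is only a floor, because compound 2 stands at a limit and not at a number: the limit of > 200000 nM in this assay, at which 1 of the 4 values shown sits. What is new is the exchange of one carboxy-substituted ring for another, which gives a 1.5-fold higher number from compound 1 to compound 4 (0.19 log units; within the scatter), so 5-carboxypyridin-3-yl and 5-carboxythiophen-2-yl cannot be told apart at this place in this assay.

The compounds shown leave open whether the carboxylic acid or the ring carrying it sets the number at this place. Also open, as far as these compounds go, is how a carboxamide in place of the carboxylic acid, or a longer chain between the amine nitrogen and the ring, would read.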